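A few compounds are considered here, and "the series" means these few. Any claim that something is new, unique, unknown or untested is made for them only; others in the source may bear on it.

Working notes on the series. The core, in one configuration as drawn, is that of compound 1, `c1cncc(N2C[C@@H]3CCNC[C@@H]32)c1`. Its mirror image is compound 2, `c1cncc(N2C[C@H]3CCNC[C@H]32)c1`. The chloro analogue is compound 3, `Clc1ccc(N2C[C@@H]3CCNC[C@@H]32)cn1`. In a functional assay on HEK293 cells for agonist activity at Neuronal acetylcholine receptor; alpha4/beta2 (Homo sapiens), read by FLIPR (a lower number here means that less compound is needed, a higher number that more compound is needed for the effect), compound 1 gives 410 nM, the second highest of the three numbers; compound 2 gives 1400 nM and compound 3 gives 37.4 nM. The step of a 3.4-fold higher number from compound 1 to compound 2 (0.53 log units; beyond the scatter) rests on (the fact that compounds 1 and 2 differ only in the configuration as drawn). The step of an 11-fold lower number from compound 1 to compound 3 (1.04 log units; beyond the scatter) is the only substitution on the aromatic ring measured so far.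

The unmeasured compound 4 is `COc1cncc(N2C[C@@H]3CCNC[C@@H]32)c1`; it differs from compound 1 by methoxy in place of hydrogen on an aromatic carbon. Among the measured compounds shown here, the chloro step shows that a substituent on the aromatic ring can move the number well beyond the scatter, in the direction of a lower value, but a methoxy at the place described here has no measured counterpart, so the size of the step cannot be taken from it directly. A modest lowering, estimated as a 1.6-fold lower number from compound 1 to compound 4 (0.21 log units; within the scatter), is expected. For compound 4 in this assay the estimate is 250 nM, with a range from 60 nM to 1000 nM.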

Compound 4, half-maximal effective concentration: 7690 nM
Beside the measured number, compound 4's estimate is 31-fold (1.49 log units) below it; measured number above the stated range.
By their numbers in this assay, from the lowest: compound 3; then compound 1; then compound 2; then compound 4.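

In this assay, methoxy in place of hydrogen gives a 19-fold higher number from compound 1 to compound 4 (1.27 log units; beyond the scatter), so a substituent on the aromatic ring of the shared core does not always lower the number. The chloro change gives the opposite direction, an 11-fold lower number from compound 1 to compound 3 (1.04 log units; beyond the scatter), and the methoxy step, on an aromatic carbon two atoms from the ring nitrogen, is larger in size than the step between the mirror images, a 3.4-fold higher number from compound 1 to compound 2 (0.53 log units; beyond the scatter). Nothing available accounts for the methoxy step.

From the compounds shown here alone, whether the rise belongs to methoxy itself or to this place on the ring remains open, as does how a hydroxy group, an amine or a longer alkoxy chain on this aromatic carbon would read. Also open, going by these compounds, is whether methoxy on the mirror-image core of compound 2 would give a step of similar size and direction.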